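Thienyl trifluoromethyl ketones: pyridyl isomer on the oxadiazole

The source may report more compounds than this note shows. Statements on the series, on what has been measured and on what is new or still open speak of the compounds shown alone.

Measured compounds:
compound 1 `O=C(c1ccc(-c2nc(-c3ccccn3)no2)s1)C(F)(F)F` 500 nM
compound 2 `O=C(NCc1ccccc1)c1ccc(C(=O)C(F)(F)F)s1` 370 nM
compound 3 `O=C(c1ccc(-c2nc(-c3cccc(C(F)(F)F)c3)no2)s1)C(F)(F)F` 2450 nM

All three share the trifluoromethyl ketone on the thiophene and were tested in an assay on isolated protein for inhibition of protein deacetylase HDAC6 (Homo sapiens); a lower number here means a stronger inhibitor, a higher number a weaker inhibitor. Compound 1 stands second highest of the three numbers. Its nearest neighbour is compound 2, whose value lies within the scatter of that of compound 1, so no order can be read between them. The furthest is compound 3, whose value lies beyond the scatter above compound 1; the two differ only in the aryl group carried on the shared core, so a change at that position can move the number markedly.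

Compound 4 `O=C(c1ccc(-c2nc(-c3cccnc3)no2)s1)C(F)(F)F` has not been measured. Relative to compound 1 the change is pyridin-3-yl in place of pyridin-2-yl on an aromatic carbon: the same atoms joined differently, the ring nitrogen moved within the six-membered ring.

Among the measured compounds shown here, no step between measured compounds covers this kind of change. The expected step is small, at most a modest weakening, and most likely within the scatter, given that compound 2 with a quite different group gives 370 nM. The step from compound 1 to compound 4 is estimated at a 1.4-fold higher number from compound 1 to compound 4 (0.15 log units; within the scatter). For compound 4 the estimate is 700 nM, with a range from 250 nM to 2000 nM.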

Compound 4, half-maximal inhibitory concentration: 840 nM
Compound 4: the middle estimate sits 1.2-fold (0.08 log units) below what was measured, within the range that was stated.
By their numbers in this assay, from the lowest: compounds 2, 1 and 4 (each within the scatter of the next, the first and the last beyond it); then compound 3.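

The swap of pyridin-3-yl for pyridin-2-yl gives a 1.7-fold higher number from compound 1 to compound 4 (0.23 log units; within the scatter) in this assay, so these two placements of the ring nitrogen cannot be told apart at this position, on the carbon of the five-membered ring that lies between two ring nitrogen atoms. The earlier compounds shown here showed only that this position can move the number markedly, with compound 3, which carries a trifluoromethyl-substituted phenyl, at 2450 nM; relocating the nitrogen within the pyridine ring does not produce a step of that kind. Nothing available here speaks to why the two isomers read alike.

On these data alone, what a plain phenyl or a pyridin-4-yl would give at this position stays open, and with it whether the ring nitrogen contributes at all to the gap between the pyridines and compound 3. Also open is how a small substituent on the pyridine ring, such as an amine, a methoxy group or a carboxylic acid, would read against the unsubstituted isomers, since the compounds shown carry none.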